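The compounds below may be only part of what the source reports. "The series", "measured", "known", "first", "only" and "open" are said of these compounds alone.

Compound 1 `O=C1CC(c2ccccc2Br)C(=O)N1CN1CCN(c2ccccc2)CC1` gives 100 mg/kg in a functional assay on the whole organism (strain CF-1 albino) with Mus musculus as the target, with a stated time of 4 h; a lower number here means that less compound is needed, a higher number that more compound is needed for the effect. Among the compounds with values here, compound 2 `O=C1CC(c2ccccc2Br)C(=O)N1CN1CCN(c2ccccc2Cl)CC1` gives 300 mg/kg in this assay, and the step of a 3.0-fold higher number from compound 1 to compound 2 (0.48 log units; beyond the scatter) places compound 2 at the highest of the two numbers measured so far, with compound 1 as its only neighbour. Compound 3 `O=C1CC(c2ccccc2Br)C(=O)N1CN1CCN(c2cccc(Cl)c2)CC1` has not yet been measured in this assay. It differs from compound 2 in one place: 3-chlorophenyl in place of 2-chlorophenyl on an amine nitrogen in a ring. Within the data shown here, the only measured step, a 3.0-fold higher number from compound 1 to compound 2 (0.48 log units; beyond the scatter), concerns adding a chlorine where there was hydrogen, not keeping the chlorine and changing which carbon of the ring carries it, so it bears on the present change only loosely; no pair compares a 2-chlorophenyl with a 3-chlorophenyl. Because compound 2 gives 300 mg/kg and the chlorine is kept, the step of a 1.5-fold lower number from compound 2 to compound 3 (0.18 log units; within the scatter) is expected to be small, not beyond the scatter, with the direction open. Compound 3 is therefore estimated at 200 mg/kg in this assay, with a range from 100 mg/kg to 400 mg/kg.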

Compound 3, minimum effective dose: 100 mg/kg
Compound 3: the middle estimate sits 2.0-fold (0.30 log units) above what was measured, within the range that was stated.
By their numbers in this assay, from the lowest: compounds 1 and 3 (each within the scatter of the next); then compound 2.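

In this assay, moving the chlorine with the atoms otherwise unchanged gives a 3.0-fold lower number from compound 2 to compound 3 (0.48 log units; beyond the scatter), so on this aromatic ring the carbon that carries the chlorine matters, not only whether a chlorine is present. Chloro in place of hydrogen was the only change read so far, and its penalty now appears tied to 2-chlorophenyl: against a 3.0-fold higher number from compound 1 to compound 2 (0.48 log units; beyond the scatter) stands no change at the digits printed from compound 1 to compound 3 (within the scatter), so 3-chlorophenyl is tolerated as well as the unsubstituted phenyl of compound 1 in this assay. Nothing measured here accounts for the difference between the two chlorophenyl groups.

On these data alone, whether the gap between 2-chlorophenyl and 3-chlorophenyl is particular to chlorine stays open, and a fluoro or methoxy group carried at the same two ring carbons would test it. Also open, as far as these compounds go, is whether any group on this phenyl ring can bring the number beneath the level shared by compound 1 and compound 3, as neither chlorophenyl isomer does so here.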